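The source may hold more compounds than are shown below. What is called first, only, known or untested is meant among the compounds shown, and "the series" means these compounds.

Measured compounds in an assay on isolated protein for binding affinity to Alpha-2C adrenergic receptor (Homo sapiens); on this read-out higher numbers stand for weaker inhibition and lower numbers for stronger inhibition:
compound 1 `C=CCc1ccccc1OCC1=NCCN1` gives 70.8 nM
compound 2 `c1ccc(OCC2=NCCN2)c(CC2CC2)c1` gives 631 nM
compound 3 `CCCc1ccccc1OC(C)C1=NCCN1` gives 148 nM

Compound 3 stands second highest of the three numbers, with compound 1 nearest and compound 2 furthest. Among the measured compounds shown here, the only step between two measured compounds that differ in one place is the one from compound 1 to compound 2, which is an 8.9-fold higher number from compound 1 to compound 2 (0.95 log units; beyond the scatter), and it sits on the chain bound to the aromatic carbon.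

Compound 4 `CCCc1ccccc1OCC1=NCCN1` is not yet measured. It differs from compound 3 in one place: hydrogen in place of methyl on a saturated chain carbon bound to a carbon with a double bond to nitrogen and an oxygen on an aromatic ring. For the measured compounds named here, no measured step bears on this position; the step from compound 1 to compound 2 concerns a different part of the molecule and gives no guide to the size or direction of a change on the chain carbon next to the oxygen. Going by the values given here, the only anchor is that compound 1 carries a hydrogen at that same carbon and gives 70.8 nM. On that basis compound 4 is expected to come out near the lower end of the measured range, with a step of a 1.9-fold lower number from compound 3 to compound 4 (0.27 log units; within the scatter) in this assay, but the confidence is limited. The estimate for compound 4 is 80 nM, with a range from 30 nM to 250 nM.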

Compound 4, inhibition constant: 490 nM
For compound 4 the middle estimate is 6.1-fold (0.79 log units) below the measured one; measured number outside the range, above it.
By their numbers in this assay, from the lowest: compound 1; then compound 3; then compounds 4 and 2 (each within the scatter of the next).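

In this assay, among the compounds shown here, the methyl on the saturated chain carbon bound to a carbon with a double bond to nitrogen and an oxygen on an aromatic ring proves to matter: hydrogen in its place gives a 3.3-fold higher number from compound 3 to compound 4 (0.52 log units; beyond the scatter), the first reading of a change at this position. The hydrogen at that carbon therefore does not by itself go with a low number, and the group on the other chain matters as well: ethyl in place of vinyl gives a 6.9-fold higher number from compound 1 to compound 4 (0.84 log units; beyond the scatter), while ethyl in place of cyclopropyl gives a 1.3-fold lower number from compound 2 to compound 4 (0.11 log units; within the scatter), so those two groups do not separate in this series and vinyl alone stands apart from them. No measurement at hand explains any of these steps.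

The methyl step is read only with the propyl-type chain of the pair shown, so whether methyl has a similar effect alongside vinyl or cyclopropyl remains open. Also open, going by these compounds, is how a hydroxyl, an amine or a longer chain at the same saturated carbon would compare with methyl and hydrogen.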